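Chloro on the Phenoxy Ring of Compound 1

The compounds below may be only part of what the source reports. "The series", "measured", "known", "first", "only" and "open" are said of these compounds alone.

Within the data shown here, compound 1 `Cc1ncc([N+](=O)[O-])n1CCOc1ccccc1` carries the higher of the two numbers so far: in a functional assay on HT-29 cells (Homo sapiens) for cytotoxicity, read by MTT assay, with a stated time of 24 h (on this read-out higher numbers stand for weaker inhibition and lower numbers for stronger inhibition), compound 1 gives 134 ug/mL, while compound 2 `Cc1ncc([N+](=O)[O-])n1CCOc1ccc(F)cc1` gives 102 ug/mL in this assay. Among the measured compounds shown here, the one measured step, a 1.3-fold lower number from compound 1 to compound 2 (0.12 log units; within the scatter), placed a fluoro in place of hydrogen on an aromatic carbon and stayed within the scatter. Compound 3 `Cc1ncc([N+](=O)[O-])n1CCOc1ccccc1Cl` differs from compound 1 by chloro in place of hydrogen on an aromatic carbon. For the measured compounds named here, only that single halogen step bears on it, so no change beyond the scatter is expected in this assay. Compound 3 is therefore estimated at 110 ug/mL, ranging from 55 ug/mL to 220 ug/mL, an expected step of a 1.2-fold lower number from compound 1 to compound 3 (0.09 log units; within the scatter).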

Compound 3, half-maximal inhibitory concentration: 552 ug/mL
Compound 3: middle estimate off by 5.0-fold (0.70 log units), on the low side; the measured number lies above the stated range.
By their numbers in this assay, from the lowest: compounds 2 and 1 (each within the scatter of the next); then compound 3.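

In this assay, chloro on an aromatic carbon ortho to a large group gives a 4.1-fold higher number from compound 1 to compound 3 (0.61 log units; beyond the scatter) and so weakens inhibition, a step that the earlier fluoro change did not show. That change gave a 1.3-fold lower number from compound 1 to compound 2 (0.12 log units; within the scatter) but differs in both the halogen and where it sits on the ring, so these two steps cannot separate the two. No measurement shown accounts for this loss.

On these data alone, it remains open whether chloro elsewhere on the ring would weaken inhibition as well. A methyl group or an amine at this place could show whether the loss is specific to chloro.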